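Swapping the aryl group on the shared core

The source may hold more compounds than are shown below. What is called first, only, known or untested is meant among the compounds shown, and "the series" means these compounds.

Of the compounds shown here, two built on the same core have been tested in a functional assay on Ehrlich cells (Mus musculus) for cytotoxicity, tested at 50 ug/mL (on this read-out lower numbers stand for a weaker effect and higher numbers for a stronger effect at the one concentration tested), so far. Compound 1 `COc1ccc(C2C(C#N)=C(N)N(c3cc(OC)c(OC)c(OC)c3)C3=C2C(=O)CC(C)(C)C3)cc1` carries a 4-methoxyphenyl on a saturated ring carbon and gives 11% in this assay. For the measured compounds named here, compound 2 `COc1ccccc1C1C(C#N)=C(N)N(c2cc(OC)c(OC)c(OC)c2)C2=C1C(=O)CC(C)(C)C2` carries a 2-methoxyphenyl there instead, and in this assay compound 2 gives 70%, the higher of the two numbers measured; the single step of a number 59 percentage points higher from compound 1 to compound 2 (beyond the scatter).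

Compound 3 `COc1cc(N2C(N)=C(C#N)C(c3ccc(C)cc3)C3=C2CC(C)(C)CC3=O)cc(OC)c1OC` has not yet been tested. It differs from compound 2 in one place: 4-methylphenyl in place of 2-methoxyphenyl on a saturated ring carbon. Going by the values given here, the only measured step that bears on this change is a number 59 percentage points higher from compound 1 to compound 2 (beyond the scatter), which shows how strongly this assay responds to a switch of the aryl group on that saturated ring carbon. Since compound 3 returns to a 4-substituted aryl, as in compound 1, a drop of similar size is expected.

Compound 3 is therefore estimated at 25% in this assay, with a likely range from 5% to 60%, a step of a number 45 percentage points lower from compound 2 to compound 3 (beyond the scatter) that is expected to run downward.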

Compound 3, a percentage reported as activity, at one concentration (the size of the read-out at that concentration, not a potency): 60%
The estimate for compound 3 lay 35 percentage points below the measured number; measured number inside the range.
By their numbers in this assay, from the lowest: compound 1; then compounds 3 and 2 (each within the scatter of the next).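

A 4-substituted aryl on the saturated ring carbon does not by itself bring a low number in this assay: replacing 2-methoxyphenyl with 4-methylphenyl leaves the reading within the usual scatter (a number 10 percentage points lower from compound 2 to compound 3 (within the scatter)). The sharper contrast now lies between two aryl groups substituted at the same ring position, where methyl in place of methoxy on an aromatic carbon makes a large difference (a number 49 percentage points higher from compound 1 to compound 3 (beyond the scatter)), so among these three compounds the low reading belongs to the 4-methoxyphenyl of compound 1 alone, and the identity of the substituent matters at least as much as where it sits. Nothing available here explains why this single swap has so large an effect.

For the compounds shown here, with only one example of each aryl group, it remains open whether compound 1 is an isolated low point or whether other groups at that spot on the aryl ring would also pull the reading down, as a chlorine, a hydroxyl or an amine in place of the methyl might show. Also open, as far as these compounds go, is what an unsubstituted phenyl would give, which would serve as a baseline for judging whether methyl and 2-methoxy add anything or 4-methoxy takes something away.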